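Compound 4 against the three measured analogues

This account rests on a few compounds, and the source may have more. Where it says the series, first, only, none or still open, it means among the compounds named here.

Among the measured compounds shown here, the series so far comprises compound 1 `COc1cc(-c2cc(/C=C/C(=O)c3ccc(N)cc3)[nH]n2)cc(OC)c1OC`, compound 2 `COc1cc(-c2cc(/C=C/C(=O)c3ccc(Cl)c(Cl)c3)[nH]n2)cc(OC)c1OC` and compound 3 `COc1ccc(C(=O)/C=C/c2cc(-c3cc(OC)c(OC)c(OC)c3)n[nH]2)cc1`. In a functional assay on MDA-MB-468 cells (Homo sapiens) for cytotoxicity, read by sulforhodamine B assay, with a stated time of 48 h, tested at 1 uM (a higher number here means a weaker effect of the compound at the concentration tested, a lower number a stronger effect), compound 1 gives 50%, compound 2 gives 76% and compound 3 gives 68%. Compound 3 thus holds the second highest of the three numbers: its nearest neighbour is compound 2, with a number 8 percentage points lower from compound 2 to compound 3 (within the scatter), and its furthest is compound 1, with a number 18 percentage points higher from compound 1 to compound 3 (beyond the scatter). The remaining step, a number 26 percentage points higher from compound 1 to compound 2 (beyond the scatter), shows that exchanging the aryl group on the carbonyl carbon can shift the read-out by a modest amount.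

Compound 4 `COc1cc(-c2cc(/C=C/C(=O)c3ccc(F)c(F)c3)[nH]n2)cc(OC)c1OC` differs from compound 3 by 3,4-difluorophenyl in place of 4-methoxyphenyl on a carbonyl carbon. For the measured compounds named here, the step that bears most directly on it is the one from compound 2 to compound 3, where a 4-methoxyphenyl replaced a 3,4-dichlorophenyl on the same carbonyl carbon and the read-out moved within the scatter. The change to compound 4 runs that exchange backwards with a 3,4-difluorophenyl, so the step of a number 4 percentage points higher from compound 3 to compound 4 (within the scatter) is expected to remain within the scatter, leaning if anything towards the number of compound 2 at 76%. For compound 4 the estimated value in this assay is therefore 72%, within a range of 58% to 86%.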

Compound 4, a percentage reported as activity, at one concentration (the size of the read-out at that concentration, not a potency): 79%
Beside the measured number, compound 4's estimate is 7 percentage points below it, and the stated range covers the measured number.
By their numbers in this assay, from the lowest: compound 1; then compounds 3, 2 and 4 (each within the scatter of the next, the first and the last beyond it).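

In this assay, among the compounds shown here, the step of a number 11 percentage points higher from compound 3 to compound 4 (beyond the scatter) (a number 3 percentage points higher from compound 2 to compound 4 (within the scatter) for the halogen exchange) gives the first exchange on this carbonyl carbon away from 4-methoxyphenyl that passes beyond the scatter, although the corresponding exchange with 3,4-dichlorophenyl stayed within it. Replacing 3,4-dichlorophenyl with 3,4-difluorophenyl therefore leaves the read-out unresolved, and the two halogenated compounds cannot be ordered, while compound 3 is separated from compound 4 but not from compound 2. The step of a number 29 percentage points higher from compound 1 to compound 4 (beyond the scatter) adds a third comparison beyond the scatter for compound 1, whose 4-aminophenyl group now gives the strongest effect at the concentration tested against all three other aryl groups on this carbon.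

From the compounds shown here alone, whether that stronger effect follows the free amine alone remains open, and a 4-dimethylaminophenyl, 4-acetamidophenyl or 4-hydroxyphenyl group on the same carbonyl carbon would bear on this. No available evidence accounts for the differences among these aryl groups.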